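Fluorine on the Shared Core Toward Compound 4

The source may hold more compounds than are shown below. What is called first, only, known or untested is meant among the compounds shown, and "the series" means these compounds.

Compound 1 `Cc1cc(C(=O)O)nn1Cc1cc(Br)ccc1OCc1ccc(F)cc1F` and compound 2 `Cc1cc(C(=O)O)nn1Cc1cc(Br)ccc1OCc1ccc(F)cc1` share a core and are measured in an assay on CHO-K1 cells for displacement of a labelled ligand from prostaglandin E2 receptor EP1 subtype (Homo sapiens) (on this read-out higher numbers stand for weaker inhibition and lower numbers for stronger inhibition), where compound 1 gives 0.525 nM and compound 2 gives 7.41 nM. The step of a 14-fold lower number from compound 2 to compound 1 (1.15 log units; beyond the scatter) rests on a single change, (fluoro in place of hydrogen on an aromatic carbon). Compound 3 `Cc1cc(C(=O)O)nn1Cc1ccccc1OCc1ccc(Cl)cc1Cl` has a different core; how it differs from compound 2 is not broken down here. In this assay compound 3 reaches only a limit, < 2000 nM, so no number is known for it (the limit of < 2000 nM in this assay, at which 1 of the 3 values shown sits). Compound 4 `Cc1cc(C(=O)O)nn1Cc1cc(F)ccc1OCc1ccc(Cl)cc1Cl` is still unmeasured and arises from compound 3 by fluoro in place of hydrogen on an aromatic carbon, the same kind of change as before, but at a place meta to a large group and para to a large group instead of ortho to a large group and meta to a fluoro group. Since compound 3 offers only a limit, the step that the limit leaves unreadable from compound 3 to compound 4 is estimated with caution, and compound 4 is expected at 60 nM, between 6 nM and 600 nM.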

Compound 4, half-maximal inhibitory concentration: 355 nM
Compound 4: middle estimate off by 5.9-fold (0.77 log units), on the low side, within the range that was stated.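

No size can be read for the step from compound 3 to compound 4, because compound 3 carries only a limit: the limit of < 2000 nM in this assay, at which 1 of the 4 values shown sits. The compounds shown leave open how much fluoro in place of hydrogen at this place changes the read-out.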